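The source may report more compounds than this note shows. Statements on the series, on what has been measured and on what is new or still open speak of the compounds shown alone.

Measured so far in a functional assay on Mahlavu cells (Homo sapiens) for antiproliferative activity, read by sulforhodamine B assay, with a stated time of 72 h; a higher number here means a weaker inhibitor, a lower number a stronger inhibitor:
compound 1 `FC(F)(F)c1ccc(CN2CCN(Cc3cc(-c4ccc(OCc5ccccc5)cc4)on3)CC2)cc1` — 11700 nM
compound 2 `Fc1ccc(COc2ccc(-c3cc(CN4CCN(Cc5ccc(C(F)(F)F)cc5)CC4)no3)cc2)cc1` — 3100 nM
compound 3 `N#Cc1cccc(COc2ccc(-c3cc(CNC4CCN(Cc5ccccc5)CC4)no3)cc2)c1` — 2100 nM

Compound 1 and compound 2 share a core and differ by fluoro in place of hydrogen on an aromatic carbon. That change gave a 3.8-fold lower number from compound 1 to compound 2 (0.58 log units; beyond the scatter). Compound 3 carries a different core; the difference between the two cores is not broken down here. Against compound 2 its number is within the scatter; against compound 1 it is well apart.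

Compound 4 `N#Cc1cccc(COc2ccc(-c3cc(CNC4CCN(Cc5ccccc5)CC4)no3)cc2F)c1` is not yet measured. It differs from compound 3 by fluoro in place of hydrogen on an aromatic carbon. Going by the values given here, this is the same kind of change as the one from compound 1 to compound 2, but not the same: there the fluoro sat para to a large group, here it sits ortho to a (3-cyanobenzyl)oxy group and meta to a large group, on another ring. Among the compounds with values here, because the only measured precedent is a 3.8-fold lower number from compound 1 to compound 2 (0.58 log units; beyond the scatter) on a different ring position, only a smaller step is expected: a 1.4-fold lower number from compound 3 to compound 4 (0.15 log units; within the scatter). Compound 4 is estimated at 1500 nM in this assay, with a range from 600 nM to 4000 nM.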

Compound 4, half-maximal inhibitory concentration: 2700 nM
Beside the measured number, compound 4's estimate is 1.8-fold (0.26 log units) below it; measured number inside the range.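

Fluoro in place of hydrogen on an aromatic carbon does not carry over as a single effect between these two cores in this assay: the same change on two cores in this assay, a 3.8-fold lower number (0.58 log units; beyond the scatter) from compound 1 to compound 2 and a 1.3-fold higher number (0.11 log units; within the scatter) from compound 3 to compound 4, 4.9-fold (0.69 log units) apart, beyond the scatter of two such steps

On the core of compound 3, with the fluoro ortho to a (3-cyanobenzyl)oxy group, the result is a 1.3-fold higher number from compound 3 to compound 4 (0.11 log units; within the scatter). The two fluoro atoms also sit on different rings, and one pair per core cannot separate the effect of the core from that of the position or support a general rule.

On these data alone, it remains open whether fluoro at the place it holds in compound 2 would give a comparable step on the core of compound 3. Also open, as far as these compounds go, is whether chloro or methoxy in place of this fluoro would move the number beyond the scatter.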